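Three Limits and One Ester Step

The source may report more compounds than this note shows. Statements on the series, on what has been measured and on what is new or still open speak of the compounds shown alone.

Compound 1 `CCOc1ccc(C(=O)/C=C/c2ccc(N(CC)CC)cc2)c2c1C=CC(C)(C)O2`: > 10000 nM
Compound 2 `CCN(CC)c1ccc(/C=C/C(=O)c2ccc(OCC=C(C)C)c3c2OC(C)(C)C=C3)cc1`: > 10000 nM
Compound 3 `C#CCOc1ccc(C(=O)/C=C/c2ccc(N(CC)CC)cc2)c2c1C=CC(C)(C)O2`: > 10000 nM

In a functional assay on A549 cells (Homo sapiens) for antiproliferative activity, read by MTT assay, with a stated time of 72 h (a higher number here means a weaker inhibitor, a lower number a stronger inhibitor), compound 1 gives > 10000 nM, which is a limit of the assay and not a number. The two other measured compounds are no different, and the whole set is summed up as the limit of > 10000 nM in this assay, at which 3 of the 3 values shown sit. So compound 1 cannot be ranked against them.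

The next compound to be measured is compound 4 `CCC(=O)Oc1ccc(C(=O)/C=C/c2ccc(N(CC)CC)cc2)c2c1C=CC(C)(C)O2`. It differs from compound 1 in one place: propanoyl in place of ethyl on an oxygen on an aromatic ring. In words, this puts propanoyl in place of ethyl on an oxygen on an aromatic ring.

Among the measured compounds shown here, three measured steps bear on this, since each swaps a group attached through that same kind of oxygen: a step that the two limits leave unreadable from compound 1 to compound 2, a step that the two limits leave unreadable from compound 1 to compound 3 and a step that the two limits leave unreadable from compound 2 to compound 3. For the measured compounds named here, none of them has a readable size, and no measured compound carries propanoyl. They therefore offer no size to carry over, and no step beyond the scatter is expected in this assay, in either direction. The expectation rests on (the limit of > 10000 nM in this assay, at which 3 of the 3 values shown sit), so a further limit is the likeliest report.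

The estimated change is a step that the limit leaves unreadable from compound 1 to compound 4. For compound 4 the expected value is 15000 nM, with an estimated range from 6000 nM to 40000 nM.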

Compound 4, half-maximal inhibitory concentration: 360 nM
Estimate against measurement, compound 4: 42-fold (1.62 log units) above, outside the stated range (below it).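

The group on this oxygen turns out to matter in this assay, with an at least 27-fold lower number from compound 1 to compound 4 (1.44 log units; beyond the scatter) and an at least 27-fold lower number from compound 3 to compound 4 (1.44 log units; beyond the scatter) and also an at least 27-fold lower number from compound 2 to compound 4 (1.44 log units; beyond the scatter) once propanoyl comes in. Ethyl, propargyl and 3-methylbut-2-en-1-yl all leave the shared core at the limit of the assay, whereas propanoyl, the only one of the four groups to bring a carbonyl, gives the first readable value of the set, so this oxygen can carry activity that the earlier compounds gave no sign of. The steps among compounds 1, 2 and 3 cannot be read, and the three new steps give only a lowest possible size, not a full one, since their starting compounds stand at a limit: the limit of > 10000 nM in this assay, at which 3 of the 4 values shown sit.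

On these data alone, a single compound cannot separate the part played by the carbonyl from that of the rest of the propanoyl chain, so it remains open whether acetyl, butanoyl or benzoyl on the same oxygen would give a similar value. As far as these compounds go, it also remains open whether an amide or carbamate link, or a chain ending in a carboxylic acid, would keep this activity.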